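The source may hold more compounds than are shown below. What is called first, only, known or untested is meant among the compounds shown, and "the series" means these compounds.

Working notes on the series, all read in a physicochemical assay for solubility, read by HPLC, using the shake flask method, in phosphate buffer, measured as kinetic solubility, with a stated time of 20 h, at pH 6.5; a lower number here means a less soluble compound, a higher number a more soluble compound. Compound 1 `Fc1ccc(Nc2cc3[nH]c(Nc4ccc(N5CCNCC5)cn4)nc3cn2)cc1C(F)(F)F` gives 180000 nM. Compound 2 `Fc1ccc(Nc2cc3[nH]c(Nc4ccc(N5CCN(C6CC6)CC5)cn4)nc3cn2)cc1C(F)(F)F` gives 5000 nM. Compound 3 `Fc1ccc(Nc2cc3[nH]c(Nc4ccc(N5CCN(CC6CC6)CC5)cn4)nc3cn2)cc1C(F)(F)F` gives 75000 nM, the second highest of the three numbers. Compound 4 `C[C@@H]1CN(c2ccc(Nc3nc4cnc(Nc5ccc(F)c(C(F)(F)F)c5)cc4[nH]3)nc2)C[C@H](C)O1` carries 2,6-dimethylmorpholin-4-yl in place of 4-(cyclopropylmethyl)piperazin-1-yl on an aromatic carbon. Going by the values given here, no measured step replaces this whole group, so the steps on the ring amine nitrogen bear only indirectly: a 36-fold lower number from compound 1 to compound 2 (1.56 log units; beyond the scatter), a 2.4-fold lower number from compound 1 to compound 3 (0.38 log units; beyond the scatter) and a 15-fold higher number from compound 2 to compound 3 (1.18 log units; beyond the scatter). Both substituents lowered the number relative to hydrogen, one modestly and one strongly, so a large downward step is expected in this assay, with compound 2 at 5000 nM as the nearest guide. The expected change is a 15-fold lower number from compound 3 to compound 4 (1.18 log units; beyond the scatter). The estimate for compound 4 is 5000 nM, within an expected range of 800 nM to 30000 nM.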

Compound 4, solubility: < 5000 nM
Compound 4: no number, only a limit; the forecaster's own chance of this, stated with the estimate: 15%; the middle value sits exactly at the limit.
By their numbers in this assay, from the lowest: compound 2; then compound 3; then compound 1.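

Compound 4 gives no number in this assay, only a limit: the limit of < 5000 nM in this assay, at which 1 of the 4 values shown sits.

Exchanging the whole group on the aromatic carbon, not only the substituent on the ring amine nitrogen, still gives a large step: an at least 15-fold lower number from compound 3 to compound 4 (1.17 log units; beyond the scatter) and an at least 36-fold lower number from compound 1 to compound 4 (1.55 log units; beyond the scatter). The remaining step shows a number no higher from compound 2 to compound 4 (the limit leaves the size open).

Open, as far as these compounds go, is how far compound 4 really lies past its limit, and whether a plain morpholin-4-yl or a piperidin-1-yl on this aromatic carbon would read the same way in this assay.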